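The compounds below may be only part of what the source reports. "The series", "measured", "known", "first", "only" and "open" are said of these compounds alone.

Measured so far in a functional assay on SMMC-7721 cells (Homo sapiens) for antiproliferative activity, read by MTT assay, with a stated time of 72 h; on this read-out lower numbers stand for stronger inhibition and higher numbers for weaker inhibition:
compound 1 `C/C(=N\NC(=O)c1cccc(S(=O)(=O)N2CCOCC2)c1)c1ccc(O)cc1`, 88500 nM
compound 2 `C/C(=N\NC(=O)c1cccc(S(=O)(=O)N2CCOCC2)c1)c1cc(Br)ccc1O`, 2410 nM
compound 3 `O=C(N/N=C/c1ccco1)c1cccc(S(=O)(=O)N2CCOCC2)c1`, > 100000 nM

Compound 3 gives only a limit of the assay, (the limit of > 100000 nM in this assay, at which 1 of the 3 values shown sits), not a number; it stands at the weak end of the three. Compound 4 `CCOc1cccc(/C=N/NC(=O)c2cccc(S(=O)(=O)N3CCOCC3)c2)c1O` differs from compound 3 by 3-ethoxy-2-hydroxyphenyl in place of furan-2-yl on a carbon with a double bond to nitrogen. Going by the values given here, no measured step changes a furan for a phenyl, so nothing shows that change directly. Among the compounds with values here, the one step that bears on the entering group is a 37-fold lower number from compound 1 to compound 2 (1.56 log units; beyond the scatter), where the phenyl carrying the hydroxyl on the carbon next to the attachment is the stronger one. From a starting limit, the step from compound 3 to compound 4 is expected to be an at least 6.6-fold lower number from compound 3 to compound 4 (0.82 log units; beyond the scatter). Compound 4 is estimated at 15000 nM, between 3000 nM and 80000 nM.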

Compound 4, half-maximal inhibitory concentration: 6990 nM
Compound 4: middle estimate off by 2.1-fold (0.33 log units), on the high side, and the stated range covers the measured number.
By their numbers in this assay, from the lowest: compound 2; then compound 4; then compound 1. At a limit, above all of these: compound 3.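

On the carbon with a double bond to nitrogen, the earlier step exchanged one phenyl for another, whereas here a substituted phenyl replaces a five-membered aromatic ring: in this assay, the change gives an at least 14-fold lower number from compound 3 to compound 4 (1.15 log units; beyond the scatter). The value of compound 3 is a limit, not a number, so the size of this step is only a lower bound: the limit of > 100000 nM in this assay, at which 1 of the 4 values shown sits.

The compounds shown do not separate the ring exchange from the hydroxyl and the ethoxy on the entering phenyl. Also open, as far as these compounds go, is how an amine or a carboxylic acid in place of the ethoxy would read in this assay.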